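The source may hold more compounds than are shown below. What is called first, only, known or untested is meant among the compounds shown, and "the series" means these compounds.

Of the compounds shown here, three have been measured in a functional assay on cells for positive allosteric modulation of metabotropic glutamate receptor 2 (Homo sapiens), read by fluorescence and calcium flux, with a stated time of 30 min; on this read-out lower numbers stand for an effect already at smaller amounts and higher numbers for an effect only at larger amounts of compound. Compound 1 `FC(F)(F)c1ccc(-c2ccc(Cn3nnc4ccccc43)cc2)c(Cl)c1` gives 37 nM, compound 2 `Fc1ccc(Cn2nnc3c(Br)cccc32)cc1` gives 15 nM, and compound 3 `Brc1cccc2c1nnn2CC1CCCC1` gives 30 nM. Compound 3 thus stands second highest of the three numbers; its gap to compound 1 and its gap to compound 2 both lie within the scatter of this assay, so the three compounds cannot be told apart on potency.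

Compound 4 `CCn1nnc2c(Br)cccc21` is not yet measured. Within the data shown here, its only difference from compound 3 is methyl in place of cyclopentyl on a saturated chain carbon bound to an aromatic nitrogen. Among the measured compounds shown here, no measured pair shows what happens when the five-carbon ring on that saturated carbon is replaced by a single carbon, so the direction of the step has to be guessed. In compounds 1, 2 and 3 the saturated carbon always carries more than one heavy atom beyond it, and cutting it back to one carbon is expected to weaken the effect in this assay, by a step of a 5.0-fold higher number from compound 3 to compound 4 (0.70 log units; beyond the scatter) beyond the scatter. Compound 4 is therefore estimated at 150 nM in this assay, with a range from 40 nM to 600 nM.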

Compound 4, half-maximal effective concentration: 2240 nM
Compound 4: middle estimate off by 15-fold (1.17 log units), on the low side, outside the stated range (above it).
By their numbers in this assay, from the lowest: compounds 2, 3 and 1 (each within the scatter of the next, the first and the last beyond it); then compound 4.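

Replacing cyclopentyl with methyl on a saturated chain carbon bound to an aromatic nitrogen gives, in this assay, a 75-fold higher number from compound 3 to compound 4 (1.87 log units; beyond the scatter) and so a large loss of effect. Among these compounds, this is the first single change seen at this position, and it shows that the group held there can matter a great deal: with the rest of the compound unchanged, compound 4 needs far larger amounts than compound 3 for the same effect. No data at hand explain the size of this step.

As far as these compounds go, whether the ring itself is needed stays open, as an open butyl chain or a cyclopropyl ring on that saturated carbon would be required to tell a ring from a mere count of carbons. Also open, from the compounds shown here alone, is how an amine or a carboxylic acid at this place would behave.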